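A few compounds are considered here, and "the series" means these few. Any claim that something is new, unique, unknown or untested is made for them only; others in the source may bear on it.

The account follows a set of compounds tested in a functional assay on H157 cells (Homo sapiens) for antiproliferative activity, read by trypan blue exclusion; on this read-out higher numbers stand for weaker inhibition and lower numbers for stronger inhibition. Compound 1 `COc1ccc(/C=C/S(=O)(=O)Cc2ccc(OC)cc2)cc1` gives only a limit of the assay there, > 20000 nM, and not a number. Among the values shown, compound 1 stands at the limit of > 20000 nM in this assay, at which 1 of the 3 values shown sits. Compound 2 `COc1cc(OC)c(/C=C/S(=O)(=O)Cc2ccc(OC)c(OC)c2OC)c(OC)c1` gives 15000 nM in this assay, and compound 3 `COc1cc(OC)c(/C=C/S(=O)(=O)Cc2ccc(Cl)cc2)c(OC)c1` gives 15000 nM. Compound 4 `COc1ccc(CS(=O)(=O)/C=C/c2ccc(F)cc2)cc1` is not yet measured; compared with compound 1 it carries fluoro in place of methoxy on an aromatic carbon. Among the compounds with values here, no step between measured compounds of this set is known, and all three values shown sit at the weak end of this assay. The step from compound 1 to compound 4 is expected to be small in this assay, with no direction beyond the scatter, estimated as a number no higher from compound 1 to compound 4 (the limit leaves the size open). Compound 4 is therefore estimated at 20000 nM, between 8000 nM and 50000 nM, and may itself return only as a limit.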

Compound 4, half-maximal inhibitory concentration: 2500 nM
Estimate against measurement, compound 4: 8.0-fold (0.90 log units) above, and the stated range ends above it.
By their numbers in this assay, from the lowest: compound 4; then compounds 2 and 3 (each within the scatter of the next). At a limit, above all of these: compound 1.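

In this assay, within the data shown here, fluoro in place of methoxy on an aromatic carbon, para to a large group, gives an at least 8.0-fold lower number from compound 1 to compound 4 (0.90 log units; beyond the scatter), the first step of this set that can be read. Among these compounds, this position answers to a single replacement, something the earlier compounds, no pair of which differ in one place, did not show. The size of the step stays open on one side because compound 1 stands at a limit: the limit of > 20000 nM in this assay, at which 1 of the 4 values shown sits.

From the compounds shown here alone, whether chloro, a nitrile or an amine on the same carbon would match fluoro stays open. Compound 4 alone cannot tell whether the gain comes from the fluoro arriving or from the methoxy leaving.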